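Swapping Methyl for Phenyl on the Core of Compound 1

A few compounds are considered here, and "the series" means these few. Any claim that something is new, unique, unknown or untested is made for them only; others in the source may bear on it.

Compound 1 `CCC(=O)c1ccc2c(c1O)[C@@H]1c3c(ccc4c(=O)c(C)c(C)oc34)OC[C@@H]1C(C)(C)O2` is examined in a functional assay on MDA-MB-231 cells (Homo sapiens) for cytotoxicity, read by MTT assay; on this read-out higher numbers stand for weaker inhibition and lower numbers for stronger inhibition. In this assay compound 1 gives only a limit, > 100000 nM. Compound 2 `CC(=O)c1ccc2c(c1O)[C@@H]1c3c(ccc4c(=O)c(C)c(C)oc34)OC[C@@H]1C(C)(C)O2` likewise gives only a limit, > 100000 nM. Compound 3 `Cc1oc2c3c(ccc2c(=O)c1C)OC[C@H]1[C@@H]3c2c(ccc(C(=O)Cc3ccccc3)c2O)OC1(C)C` also gives only a limit, > 100000 nM. Because all three sit at one limit (the limit of > 100000 nM in this assay, at which 3 of the 3 values shown sit), the steps a step that the two limits leave unreadable from compound 1 to compound 2, a step that the two limits leave unreadable from compound 1 to compound 3 and a step that the two limits leave unreadable from compound 2 to compound 3 cannot be read, and each changes only the saturated chain carbon bound to the carbonyl carbon. Compound 4 `CCC(=O)c1ccc2c(c1O)[C@@H]1c3c(ccc4c(=O)c(-c5ccccc5)c(C)oc34)OC[C@@H]1C(C)(C)O2` differs from compound 1 elsewhere: phenyl in place of methyl on an aromatic carbon. Among the compounds with values here, no measured step touches this aromatic position, so no gain beyond the scatter is expected, and the expected step from compound 1 to compound 4 is a number no higher from compound 1 to compound 4 (the limit leaves the size open). Compound 4 is estimated at 100000 nM, between 30000 nM and 300000 nM, most likely again only a limit.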

Compound 4, half-maximal inhibitory concentration: 6150 nM
Beside the measured number, compound 4's estimate is 16-fold (1.21 log units) above it, outside the stated range (below it).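

In this assay, phenyl in place of methyl on an aromatic carbon gives an at least 16-fold lower number from compound 1 to compound 4 (1.21 log units; beyond the scatter). Within the data shown here, this aromatic position therefore responds to change on the shared core, and compound 4 is the only one of the four compounds with a value that is a number and not a limit. The steps at the saturated chain carbon bound to the carbonyl carbon still cannot be read: the limit of > 100000 nM in this assay, at which 3 of the 4 values shown sit.

Only methyl and phenyl are shown at this aromatic carbon, so it remains open whether an aromatic ring is needed there or whether a longer chain or an amine would serve as well. Also open, as far as these compounds go, is whether phenyl at this position would lower the number on the cores of compound 2 and compound 3.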